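The compounds below may be only part of what the source reports. "The series", "measured", "known", "first", "only" and "open" are said of these compounds alone.

Series notes. Two compounds on the shared core have been run in a functional assay on the whole organism (strain albino) for inhibition, with Rattus norvegicus as the target, read by paw edema, with a stated time of 2 h, at a dose of 0.28 mmol/kg by the oral route; on this read-out higher numbers stand for more inhibition at the one dose given (going by the name of the read-out) and lower numbers for less inhibition. Compound 1 `C=CCn1c(SC/C(=N\O)c2ccccc2)nnc1-c1ccc(OC)c(OC)c1` gives 57% in this assay. Compound 2 `COc1ccc(-c2nnc(SCC(=O)c3ccccc3)n2-c2ccccc2)cc1OC` gives 57% in this assay, so compound 2 stands level with compound 1 to the digits reported; the two values lie within the scatter of each other, and no order between them is read. Going by the values given here, no pair of measured compounds differs in one place, so no step size is on record for this series.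

Compound 3 `C=CCn1c(SCC(=O)c2ccccc2)nnc1-c1ccc(OC)c(OC)c1` has not yet been measured. It differs from compound 2 as follows: allyl in place of phenyl on an aromatic nitrogen. The allyl that enters is the group compound 1 carries on the same aromatic nitrogen, while the (benzoylmethyl)sulfanyl group of compound 2 is retained.

For compound 3 in this assay no change beyond the scatter is expected in either direction, since compound 1 with the allyl gives 57% and compound 2 with the phenyl gives 57%. The expected step is a number 2 percentage points lower from compound 2 to compound 3 (within the scatter). Compound 3 is estimated at 55% in this assay, with a range from 40% to 70%.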

Compound 3, a percentage reported as inhibition, in the whole organism at one dose (the size of the read-out at that dose, not a potency): 63%
For compound 3 the middle estimate is 8 percentage points below the measured one; the range from low to high includes it.
By their numbers in this assay, from the lowest: compounds 1, 2 and 3 (each within the scatter of the next).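

Going by these compounds alone, on the aromatic nitrogen, allyl in place of phenyl with the (benzoylmethyl)sulfanyl group held gives a number 6 percentage points higher from compound 2 to compound 3 (within the scatter) in this assay, the first step on record at this position, so exchanging the six-carbon aromatic ring for the three-carbon group with no ring moves the read-out by no more than the scatter. With the allyl held, changing the group on a saturated chain carbon bound to a sulfur gives a number 6 percentage points higher from compound 1 to compound 3 (within the scatter), so neither of the two single changes now on record separates its pair of compounds in this assay. No measurement in hand bears on why these values lie as they do.

From the compounds shown here alone, whether a benzyl or a longer chain such as n-butyl on the aromatic nitrogen, or a carboxylic acid in place of a methoxy on the 3,4-dimethoxyphenyl group, would carry the read-out beyond the scatter remains open. Going by these compounds, with each compound read at a single dose, how the three would stand across a range of doses also remains open.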